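Chloro for fluoro on the anilino ring of the shared core

A few compounds are considered here, and "the series" means these few. Any claim that something is new, unique, unknown or untested is made for them only; others in the source may bear on it.

Measured so far:
compound 1 `N#Cc1c(Nc2ccccc2Cl)nc(SCc2cn(Cc3ccccc3Cl)nn2)nc1-c1ccccc1`: 28500 nM
compound 2 `Cc1ccc(Cn2cc(CSc3nc(Nc4ccccc4F)c(C#N)c(-c4ccccc4)n3)nn2)cc1`: > 64000 nM

Compound 1 gives 28500 nM in a functional assay on ECa-109 cells (Homo sapiens) for inhibition, read by MTT assay, with a stated time of 72 h; a lower number here means a stronger inhibitor, a higher number a weaker inhibitor. For compound 2 this assay reports only a limit, > 64000 nM, so compound 2 sits at the edge of what this assay can resolve, as noted in the limit of > 64000 nM in this assay, at which 1 of the 2 values shown sits. Within the data shown here, no step between measured compounds is available, and compound 1 and compound 2 differ in more than one place, so their two values are only read side by side.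

The step to compound 3 `Cc1ccc(Cn2cc(CSc3nc(Nc4ccccc4Cl)c(C#N)c(-c4ccccc4)n3)nn2)cc1` is chloro in place of fluoro on an aromatic carbon. Among the measured compounds shown here, compound 1 carries the (2-chlorophenyl)amino group too and returns a measurable number, which is the only hint that this change may bring compound 3 back inside the range of this assay. The expected step from compound 2 to compound 3 is an at least 1.6-fold lower number from compound 2 to compound 3 (0.20 log units; that floor lies within the scatter), toward stronger inhibition but modest, since compound 2 shows only a limit. Compound 3 is estimated at 40000 nM in this assay, with a range from 15000 nM to 100000 nM, and a real chance that it too is reported only as a limit.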

Compound 3, half-maximal inhibitory concentration: 11200 nM
The estimate for compound 3 lay 3.6-fold (0.55 log units) above the measured number, outside the stated range (below it).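

In this assay, with the 4-methylphenyl group held constant, the change from (2-fluorophenyl)amino to (2-chlorophenyl)amino gives an at least 5.7-fold lower number from compound 2 to compound 3 (0.75 log units; beyond the scatter), which shows that this single halogen swap on the anilino ring is enough to bring the series back inside the measurable range. The size of this step remains a floor and not a full measure, because the value for compound 2 is only a limit: the limit of > 64000 nM in this assay, at which 1 of the 3 values shown sits. With the (2-chlorophenyl)amino group held constant, 4-methylphenyl in place of 2-chlorophenyl gives a 2.5-fold lower number from compound 1 to compound 3 (0.41 log units; beyond the scatter), so the number also responds to the group at the far end of the molecule and does not depend on the anilino chloro alone.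

The compounds shown carry only fluoro and chloro at the anilino position, so it remains open how a bromo, a methyl or a methoxy group would read there. It also remains open whether the two changes add up, since the compounds shown do not combine the 2-chlorophenyl group with the (2-fluorophenyl)amino group.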